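Series notes: ring-nitrogen substituent and metabolic stability

A few compounds are considered here, and "the series" means these few. Any claim that something is new, unique, unknown or untested is made for them only; others in the source may bear on it.

Compound 1 `CN1CCN(CCCN(C[C@H]2Cc3ccccc3CN2)[C@H]2CCCc3cccnc32)CC1` gives 53% in an ADME assay on microsomes from liver (Mus musculus) for metabolic stability, read by LC-MS, with a stated time of 10 min, tested at 0.5 uM (a higher number here means that more of the compound is left, a lower number that less of the compound is left), the second highest of the three values; compound 2 `c1ccc2c(c1)CN[C@@H](CN(CCCN1CCNCC1)[C@H]1CCCc3cccnc31)C2` gives 92% and compound 3 `NC(=O)N1CCN(CCCN(C[C@H]2Cc3ccccc3CN2)[C@H]2CCCc3cccnc32)CC1` gives 42%. The step to compound 4 `c1ccc2c(c1)CN[C@@H](CN(CCCN1CCN(C3CC3)CC1)[C@H]1CCCc3cccnc31)C2` is cyclopropyl in place of methyl on an amine nitrogen in a ring. Among the measured compounds shown here, no measured step replaces methyl with cyclopropyl at this position; the two that bear on it vary the same ring nitrogen: a number 39 percentage points higher from compound 1 to compound 2 (beyond the scatter) and a number 11 percentage points lower from compound 1 to compound 3 (beyond the scatter). Both are beyond the scatter, with opposite directions. A cyclopropyl group is a carbon substituent like methyl rather than hydrogen or carbamoyl, so for compound 4 a small downward step or none beyond the scatter is expected: a number 8 percentage points lower from compound 1 to compound 4 (within the scatter). Compound 4 is estimated at 45%, within 25% to 65%.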

Compound 4, percent of the compound remaining: 3%
Compound 4: the middle estimate sits 42 percentage points above what was measured; the measured number lies below the stated range.
By their numbers in this assay, from the lowest: compound 4; then compound 3; then compound 1; then compound 2.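

In this assay this ring nitrogen can also give a very low number, and a carbon substituent does not guarantee a result like that of methyl (a number 50 percentage points lower from compound 1 to compound 4 (beyond the scatter)). Cyclopropyl also stands apart from carbamoyl (a number 39 percentage points lower from compound 3 to compound 4 (beyond the scatter)) and from hydrogen (a number 89 percentage points lower from compound 2 to compound 4 (beyond the scatter)), so it gives the lowest number of the four substituents, with every step to it beyond the scatter. No measurement at hand explains this drop.

On these data alone, whether the low number is particular to the three-membered ring remains open. Ethyl or cyclobutyl on the same nitrogen would show whether it extends to other carbon substituents.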